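Swapping the aryl amine on a quinazoline-like core

The source may hold more compounds than are shown below. What is called first, only, known or untested is meant among the compounds shown, and "the series" means these compounds.

Compound 1: `CCS(=O)(=O)Nc1cc(-c2ccc3ncnc(Nc4ccc(F)cc4)c3c2)cnc1OC` — 2400 nM
Compound 2: `CCS(=O)(=O)Nc1cc(-c2ccc3ncnc(Nc4ccc(OC)c(OC)c4)c3c2)cnc1OC` — 1680 nM
Compound 3: `CCS(=O)(=O)Nc1cc(-c2ccc3ncnc(Nc4cccc(C(=O)OC)c4)c3c2)cnc1OC` — 1120 nM

Three compounds share one core and differ only in the group on a nitrogen on an aromatic ring. In a functional assay on SNU-638 cells (Homo sapiens) for cytotoxicity, read by sulforhodamine B assay, with a stated time of 72 h (a higher number here means a weaker inhibitor, a lower number a stronger inhibitor), compound 3 gives the lowest of the three numbers; compound 2 sits within the scatter of it, while compound 1 lies beyond it, as the step of a 2.1-fold lower number from compound 1 to compound 3 (0.33 log units; beyond the scatter) shows. The step of a 1.4-fold lower number from compound 1 to compound 2 (0.15 log units; within the scatter) and the step of a 1.5-fold lower number from compound 2 to compound 3 (0.18 log units; within the scatter) are both within the scatter, so the whole set spans a modest range.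

Compound 4, `CCS(=O)(=O)Nc1cc(-c2ccc3ncnc(Nc4ccc(OC)nc4)c3c2)cnc1OC`, carries the change (6-methoxypyridin-3-yl in place of 3-(methoxycarbonyl)phenyl on a nitrogen on an aromatic ring). For the measured compounds named here, the steps that bear on it are those at the same place: from compound 1 and compound 2 to compound 3, all of them modest or within the scatter. The entering group shares a methoxy substituent with the group of compound 2. The step of a 1.6-fold higher number from compound 3 to compound 4 (0.21 log units; within the scatter) is therefore expected to stay within the scatter, with compound 4 expected at 1800 nM, between 700 nM and 4500 nM.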

Compound 4, half-maximal inhibitory concentration: 4280 nM
For compound 4 the middle estimate is 2.4-fold (0.38 log units) below the measured one; low and high end bracket the measured number.
By their numbers in this assay, from the lowest: compounds 3, 2, 1 and 4 (each within the scatter of the next, the first and the last beyond it).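

In this assay, this position gives a wider spread than the first three compounds showed: a 3.8-fold higher number from compound 3 to compound 4 (0.58 log units; beyond the scatter) is larger than any earlier step at this place, and a 2.5-fold higher number from compound 2 to compound 4 (0.41 log units; beyond the scatter) also lies beyond the scatter, even though the groups of compound 2 and compound 4 share a methoxy substituent. A shared methoxy substituent therefore did not keep these two values together, whereas a 1.8-fold higher number from compound 1 to compound 4 (0.25 log units; within the scatter) stays within the scatter. Nothing available here explains these differences. On these data alone, it remains open whether a methoxyphenyl group, with carbon in place of the ring nitrogen of the 6-methoxypyridin-3-yl group, would read closer to compound 2 or to compound 4. Also open, as far as these compounds go, is how a carboxylic acid or a primary amide would read in place of the methyl ester of compound 3.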